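The source may report more compounds than this note shows. Statements on the series, on what has been measured and on what is new or still open speak of the compounds shown alone.

The compounds measured so far, with their values in a functional assay on LNCaP cells (Homo sapiens) for antiproliferative activity; on this read-out lower numbers stand for stronger inhibition and higher numbers for weaker inhibition:

Compound 1, `CC(=O)NCC[C@@H]1C[C@@H](c2ccc(F)c(F)c2)[C@H](NC(=O)c2cc(-c3c(Cl)cnn3C)c(Cl)o2)CN1`, gives 130 nM.
Compound 2, `Cn1ncc(Cl)c1-c1cc(C(=O)N[C@@H]2CN[C@H](CCO)C[C@H]2c2ccc(F)c(F)c2)oc1Cl`, gives 60 nM.
Compound 3, `COCC[C@@H]1C[C@@H](c2ccc(Cl)c(Cl)c2)[C@H](NC(=O)c2cc(-c3c(Cl)cnn3C)c(Cl)o2)CN1`, gives 250 nM.

Compound 3 stands at the highest of the three numbers. Its nearest neighbour is compound 1, whose value sits within the scatter of repeated measurements, so the two cannot be told apart; compound 2 lies clearly further away, beyond the scatter.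

Compound 4, `Cn1ncc(Cl)c1-c1cc(C(=O)N[C@@H]2CN[C@H](CCCO)C[C@H]2c2ccc(Cl)c(Cl)c2)oc1Cl`, is built from the same atoms as compound 3 but joined differently: hydroxymethyl in place of methoxy on a saturated chain carbon, two bonds along the chain from a saturated ring carbon. Among the measured compounds shown here, the one measured step that bears on this is a 2.2-fold lower number from compound 1 to compound 2 (0.34 log units; beyond the scatter), where a free hydroxy at the end of the chain went together with a modest drop in the number. The present change likewise uncovers a hydroxyl where compound 3 carries a methoxy, so a modest step downward in this assay is expected, with the dichloro ring of compound 3 kept. Compound 4 is therefore estimated at 150 nM, within a range from 60 nM to 400 nM, which would mean an expected step of a 1.7-fold lower number from compound 3 to compound 4 (0.22 log units; within the scatter).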

Compound 4, half-maximal inhibitory concentration: 210 nM
For compound 4 the middle estimate is 1.4-fold (0.15 log units) below the measured one; measured number inside the range.
By their numbers in this assay, from the lowest: compound 2; then compounds 1, 4 and 3 (each within the scatter of the next).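

In this assay, exchanging the 2-methoxyethyl chain for the 3-hydroxypropyl chain gives a 1.2-fold lower number from compound 3 to compound 4 (0.08 log units; within the scatter), so these two chains cannot be told apart at this position. This pair therefore shows that swapping methoxy for hydroxymethyl, which adds a hydrogen-bond donor and keeps the heavy-atom count, does not by itself move the number beyond the scatter, whereas the earlier step of a 2.2-fold lower number from compound 1 to compound 2 (0.34 log units; beyond the scatter) involved a different change, hydroxy in place of acetamido. Nothing available explains why this exchange leaves the number within the scatter.

Still open, from the compounds shown here alone, is whether a primary amine or a carboxylic acid at the end of this chain would shift the number beyond the scatter. Going by these compounds, it is also open whether a longer chain ending in hydroxy would behave like the 3-hydroxypropyl chain.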